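The compounds below may be only part of what the source reports. "The series", "measured", "known", "first", "only" and "open" are said of these compounds alone.

Compound 1 `CCCn1c(=O)[nH]c2nc(-c3ccc(S(=O)(=O)N4CCN(c5ccc(F)cc5)CC4)cc3)[nH]c2c1=O` carries a 4-fluorophenyl group on the ring nitrogen of the piperazine-type amine that hangs from the sulfonyl group of the shared core. For the measured compounds named here, in an assay on CHO cells for displacement of a labelled ligand from adenosine receptor A2b (Homo sapiens), read by scintillation counting, with a stated time of 75 min, in the presence of a further agent that is not named here (a higher number here means a weaker inhibitor, a lower number a stronger inhibitor), compound 1 gives 0.644 nM, the highest of the three numbers measured so far. Compound 2 `CCCn1c(=O)[nH]c2nc(-c3ccc(S(=O)(=O)N4CCN(c5ccccc5Br)CC4)cc3)[nH]c2c1=O`, which bears 2-bromophenyl at the same place, gives 0.137 nM, and the step of a 4.7-fold lower number from compound 1 to compound 2 (0.67 log units; beyond the scatter) is a modest one that lies beyond the scatter. Compound 3 `CCCn1c(=O)[nH]c2nc(-c3ccc(S(=O)(=O)N4CCN(Cc5ccc(Br)c(F)c5)CC4)cc3)[nH]c2c1=O`, with 4-bromo-3-fluorobenzyl on that amine nitrogen, gives 0.473 nM, and the step of a 1.4-fold lower number from compound 1 to compound 3 (0.13 log units; within the scatter) stays within the scatter, while a 3.5-fold higher number from compound 2 to compound 3 (0.54 log units; beyond the scatter) is again modest.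

Compound 4 `CCCn1c(=O)[nH]c2nc(-c3ccc(S(=O)(=O)N4CCN(Cc5ccc(Br)cc5)CC4)cc3)[nH]c2c1=O` is not yet measured. It differs from compound 1 in one place: 4-bromobenzyl in place of 4-fluorophenyl on an amine nitrogen in a ring. Going by the values given here, the step most like it is the one from compound 1 to compound 3, where a benzyl group bearing bromine also replaced 4-fluorophenyl and produced no change beyond the scatter. The step to compound 2, where a phenyl group stayed attached directly to the nitrogen, bears less directly on it. Compound 4 is therefore expected to sit close to compound 1, with a step of about a 1.4-fold lower number from compound 1 to compound 4 (0.16 log units; within the scatter), and its value in this assay is estimated at 0.45 nM, within a range from 0.2 nM to 1 nM.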

Compound 4, inhibition constant: 0.153 nM
For compound 4 the middle estimate is 2.9-fold (0.47 log units) above the measured one; the whole stated range lies above it.
By their numbers in this assay, from the lowest: compounds 2 and 4 (each within the scatter of the next); then compounds 3 and 1 (each within the scatter of the next).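

In this assay, the outcome for a benzyl group bearing bromine on this amine nitrogen depends on what else the ring carries: a 4.2-fold lower number from compound 1 to compound 4 (0.62 log units; beyond the scatter) lies beyond the scatter, whereas the step to compound 3 stayed within it. The fluoro on the aromatic carbon of compound 3 therefore matters at this position, since with hydrogen in its place there is a 3.1-fold lower number from compound 3 to compound 4 (0.49 log units; beyond the scatter), a modest step that is also beyond the scatter. The remaining step, a 1.1-fold higher number from compound 2 to compound 4 (0.05 log units; within the scatter), stays within the scatter, so 4-bromobenzyl and 2-bromophenyl cannot be told apart here, even though one is a benzyl group and the other a phenyl group.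

Nothing measured on these compounds accounts for these steps. The compounds shown also leave open whether the bromine of compound 4 contributes at all, which an unsubstituted benzyl or a 4-chlorobenzyl group on the same nitrogen would address, and how a longer chain such as 2-phenylethyl, or a benzyl group carrying a carboxylic acid, would compare.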